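Methyl to Chloro on the Phenol Ring: Cytotoxicity Outlook

The compounds below may be only part of what the source reports. "The series", "measured", "known", "first", "only" and "open" are said of these compounds alone.

Measured compounds:
compound 1 `C[C@@H]1CCC[C@H](C)N1CCCCNC(=O)c1cc(Cl)ccc1O`
compound 2 `Cc1ccc(O)c(C(=O)NCCCCN2[C@H](C)CCC[C@@H]2C)c1`
compound 3 `Cc1ccc(O)c(C(=O)NCCCN2CCC[C@@H]3CCCC[C@H]32)c1`

Three amides were tested in a functional assay on MDBK cells (Bos taurus) for cytotoxicity; on this read-out lower numbers stand for higher toxicity in this test and higher numbers for lower toxicity in this test. Compound 1 gives 100 ug/mL. Compound 2 reaches only > 100 ug/mL, which is a limit of the assay and not a number. Compound 3 gives 60 ug/mL, and its distance from compound 1 is within the scatter. The difference between the core of compound 3 and the core of compound 2 is not broken down here.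

Compound 2 and compound 1 differ by one change, (chloro in place of methyl on an aromatic carbon), and the step of a number no higher from compound 2 to compound 1 (the limit leaves the size open) because one end of it sits at the limit of > 100 ug/mL in this assay, at which 1 of the 3 values shown sits.

The untested compound 4 `O=C(NCCCN1CCC[C@@H]2CCCC[C@H]21)c1cc(Cl)ccc1O` carries the same change relative to compound 3, (chloro in place of methyl on an aromatic carbon), at the same place. In this assay compound 4 is therefore expected to show a step of a 1.3-fold lower number from compound 3 to compound 4 (0.12 log units; within the scatter), no higher in number, resting on the step from compound 2 to compound 1, whose size the limit leaves open. The estimate for compound 4 is 45 ug/mL, between 20 ug/mL and 100 ug/mL.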

Compound 4, half-maximal cytotoxic concentration: 45 ug/mL
The estimate for compound 4 equals the measured number at the digits printed; the range from low to high includes it.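

In this assay, chloro in place of methyl on the aromatic carbon gives a 1.3-fold lower number from compound 3 to compound 4 (0.12 log units; within the scatter), so on the core of compound 3 the change produces no difference beyond the scatter. Set beside the same change on the core of compound 2, the comparison of the two steps stands as follows: the same change on two cores in this assay, a number no higher (the limit leaves the size open) from compound 2 to compound 1 and a 1.3-fold lower number (0.12 log units; within the scatter) from compound 3 to compound 4; the limit leaves it open whether they differ This shows that the change gives no higher number on either core, but it does not show that the step keeps the same size from one core to the other, and the size of the earlier step cannot be read because compound 2 stands at a limit of the assay, which is not a number: the limit of > 100 ug/mL in this assay, at which 1 of the 4 values shown sits.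

The compounds shown leave open what fluoro, methoxy or a carboxylic acid would give in the place of chloro on the same aromatic carbon. They also leave open whether the small step seen with the 5-chloro-2-hydroxyphenyl group in compound 4 would recur on any further core.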